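The source may hold more compounds than are shown below. What is called first, only, known or untested is meant among the compounds shown, and "the series" means these compounds.

Measured compounds in an assay on isolated protein for antagonist activity at transient receptor potential cation channel subfamily V member 1 (Homo sapiens); a lower number here means a stronger inhibitor, a higher number a weaker inhibitor:
compound 1 `O=C(Nc1ccccc1Br)N1CCN(c2ccnc(Cl)n2)CC1` gives 1070 nM
compound 2 `O=C(Nc1ccccc1F)N1CCN(c2ccnc(Cl)n2)CC1` gives 787 nM
compound 3 `O=C(Nc1ccccc1C(F)(F)F)N1CCN(c2ccnc(Cl)n2)CC1` gives 136 nM

Compound 3 stands lowest of the three numbers in this assay; its nearest neighbour is compound 2, which gives 787 nM, and the furthest is compound 1, which gives 1070 nM. Both steps to compound 3 are beyond the scatter: a 7.9-fold lower number from compound 1 to compound 3 (0.90 log units; beyond the scatter) and a 5.8-fold lower number from compound 2 to compound 3 (0.76 log units; beyond the scatter), whereas a 1.4-fold lower number from compound 1 to compound 2 (0.13 log units; within the scatter).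

Compound 4 `CC(C)c1ccccc1NC(=O)N1CCN(c2ccnc(Cl)n2)CC1` differs from compound 3 in one place: isopropyl in place of trifluoromethyl on an aromatic carbon. The two measured steps that bear on this position, from bromo and from fluoro to trifluoromethyl, both gave modest drops, so the trifluoromethyl carries the lowest number here. No measured step shows what isopropyl does at this carbon, and no listed compound carries it. With that gap, the step is expected to be small, most likely a slight rise toward the numbers of compound 1 and compound 2: a 1.8-fold higher number from compound 3 to compound 4 (0.26 log units; within the scatter). Compound 4 is therefore estimated at 250 nM, within 80 nM to 800 nM.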

Compound 4, half-maximal inhibitory concentration: 7530 nM
For compound 4 the middle estimate is 30-fold (1.48 log units) below the measured one, outside the stated range (above it).
By their numbers in this assay, from the lowest: compound 3; then compounds 2 and 1 (each within the scatter of the next); then compound 4.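

In this assay, going by these compounds alone, the earlier compounds showed only that this carbon, ortho to a large group, could move the number by modest steps among bromo, fluoro and trifluoromethyl. Isopropyl shows that the position can also tolerate a change far less well: replacing trifluoromethyl gives the largest step seen here (a 55-fold higher number from compound 3 to compound 4 (1.74 log units; beyond the scatter)), although neither group has a ring, a hydrogen-bond donor or acceptor, or a net charge. Isopropyl also falls behind fluoro (a 9.6-fold higher number from compound 2 to compound 4 (0.98 log units; beyond the scatter)) and bromo (a 7.0-fold higher number from compound 1 to compound 4 (0.85 log units; beyond the scatter)), making compound 4 the weakest of the four, and nothing available explains this loss.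

Whether the loss is particular to isopropyl remains open, since methyl, ethyl and tert-butyl are absent from the compounds shown. Also open, going by these compounds, is how a methoxy group or a nitrile would behave on this carbon.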